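Cytotoxicity notes: replacing the pyridinyloxy arm

A few compounds are considered here, and "the series" means these few. Any claim that something is new, unique, unknown or untested is made for them only; others in the source may bear on it.

Measured in this series:
compound 1 `O=C(Nc1cccc(Oc2nccc(C(F)(F)F)c2Cl)c1)C1CCCN(C(=O)c2cc(C(F)(F)F)cc(C(F)(F)F)c2)C1`: 0%
compound 2 `O=C(Nc1ccc(Cl)cc1)C1CCCN(C(=O)c2ccc(-c3ccco3)cc2)C1`: 6%
compound 3 `O=C(Nc1ccc(Cl)cc1)C1CCCN(C(=O)c2cccc(-c3nccs3)c2)C1`: 32%

All three numbers come from an ADME assay on PC-3 cells (Homo sapiens) for cytotoxicity, read by WST assay, tested at 100 uM; on this read-out lower numbers stand for less inhibition and higher numbers for more inhibition at the one concentration tested (going by the name of the read-out). Compound 1 sits at the low end of the set; compound 2 lies within the usual scatter of it, while compound 3 lies beyond the scatter, higher. Compound 4 `O=C(Nc1cccc(S(=O)(=O)N2CCCC2)c1)C1CCCN(C(=O)c2cc(C(F)(F)F)cc(C(F)(F)F)c2)C1` differs from compound 1 by (pyrrolidin-1-yl)sulfonyl in place of (3-chloro-4-(trifluoromethyl)pyridin-2-yl)oxy on an aromatic carbon. No measured pair shows this change, so nothing shown tells its size or direction. Compound 1 reads at the floor of the read-out, which leaves little room downward. The step of a number 5 percentage points higher from compound 1 to compound 4 (within the scatter) is expected to stay within the scatter. Compound 4 is expected to give 5%, between 0% and 20%.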

Compound 4, a percentage reported as inhibition, at one concentration (the size of the read-out at that concentration, not a potency): 0%
Estimate against measurement, compound 4: 5 percentage points above; the range from low to high includes it.
By their numbers in this assay, from the lowest: compounds 1, 4 and 2 (each within the scatter of the next); then compound 3.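

Within the data shown here, replacing (3-chloro-4-(trifluoromethyl)pyridin-2-yl)oxy with (pyrrolidin-1-yl)sulfonyl on this aromatic carbon gives no change at the digits printed from compound 1 to compound 4 (within the scatter) in this assay and is the first direct reading at this position. The number is therefore level with either group at this position, although compound 1 already sits at the floor, so any further fall could not show. No available evidence bears on this result. Still open, on these data alone, is whether an amine or a carboxylic acid on this aromatic carbon would also leave the read-out at the floor.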